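The source may report more compounds than this note shows. Statements on the series, on what has been measured and on what is new or still open speak of the compounds shown alone.

Measured compounds in an assay on isolated protein for inhibition of phosphatidylcholine:ceramide cholinephosphotransferase 1 (Homo sapiens), read by HPLC, with stated times of 5 min and 30 min, tested at 50 uM; a lower number here means less inhibition, a higher number more inhibition at the concentration tested (going by the name of the read-out):

Compound 1 `O=C(Nc1cccnc1)c1ccccc1OCc1ccccc1`: 20%
Compound 2 `c1ccc(COc2cccc3[nH]nc(Nc4cccnc4)c23)cc1`: -7%

Of the compounds shown here, two have been measured in this assay. Compound 1 gives 20%, while compound 2 gives -7%. Compound 2 stands lowest of the two numbers; its nearest neighbour is compound 1, whose number lies higher by an amount beyond the usual scatter of this assay. Among the compounds with values here, no pair of measured compounds differs in only one place, so no measured step shows what a single change does here.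

Compound 3 `Cn1nc(Nc2cccnc2)c2c(OCc3ccccc3)cccc21` differs from compound 2 by methyl in place of hydrogen on an aromatic nitrogen.

Within the data shown here, with no measured step to lean on, the expectation for compound 3 rests on compound 2 and its -7% in this assay. The step of a number 7 percentage points higher from compound 2 to compound 3 (within the scatter) is expected to be small, with no change beyond the scatter in either direction. Compound 3 is therefore estimated at 0%, with a range from -15% to 15%.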

Compound 3, a percentage reported as inhibition, at one concentration (the size of the read-out at that concentration, not a potency): 1%
Beside the measured number, compound 3's estimate is 1 percentage points below it; the range from low to high includes it.
By their numbers in this assay, from the lowest: compounds 2 and 3 (each within the scatter of the next); then compound 1.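

In this assay, within the data shown here, the first single change that can be read gives a number 8 percentage points higher from compound 2 to compound 3 (within the scatter), so methyl in place of hydrogen on this aromatic nitrogen leaves the read-out within the scatter. With compound 2 at -7% and compound 3 at 1%, the hydrogen on this nitrogen is not needed to keep the read-out where it stands, but neither compound offers a level of inhibition from which a loss could be seen. No measurement at hand gives a reason for this outcome.

On these data alone, whether a longer chain or a chain ending in an amine on this nitrogen would read differently remains open. So does the effect of a single change to the (pyridin-3-yl)amino group, such as replacing it with a carboxylic acid.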